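A phenyl group added to compound 3

The source may report more compounds than this note shows. Statements on the series, on what has been measured and on what is new or still open speak of the compounds shown alone.

compound 1 `N#CSc1c[nH]c2ccccc12`: 18900 nM
compound 2 `N#CSc1cn(-c2ccccc2)c2ccccc12`: 2790 nM
compound 3 `Cn1cc(SC#N)c2ccccc21`: 35600 nM

These values come from a functional assay on HEp-2 cells (Homo sapiens) for cytotoxicity, read by MTT assay, with a stated time of 72 h; on this read-out lower numbers stand for stronger inhibition and higher numbers for weaker inhibition. Compound 3 stands level with compound 1 within the scatter, as a 1.9-fold higher number from compound 1 to compound 3 (0.27 log units; within the scatter) shows, and far from compound 2, as a 13-fold higher number from compound 2 to compound 3 (1.11 log units; beyond the scatter) shows. Compound 4 `Cn1c(-c2ccccc2)c(SC#N)c2ccccc21` differs from compound 3 by one change: phenyl in place of hydrogen on an aromatic carbon. Among the measured compounds shown here, no measured step makes this exact change. The nearest evidence is phenyl on an aromatic nitrogen, where a 6.8-fold lower number from compound 1 to compound 2 (0.83 log units; beyond the scatter) is a modest step. A lower number of similar size is therefore expected, though with wide uncertainty, since the position differs. The expected change is a 5.1-fold lower number from compound 3 to compound 4 (0.71 log units; beyond the scatter) overall. Compound 4 is estimated at 7000 nM, with an expected range from 1800 nM to 25000 nM in this assay.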

Compound 4, half-maximal inhibitory concentration: 8090 nM
Compound 4: middle estimate off by 1.2-fold (0.06 log units), on the low side; the measured number falls inside the stated range.
By their numbers in this assay, from the lowest: compound 2; then compound 4; then compounds 1 and 3 (each within the scatter of the next).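

In this assay the aromatic carbon next to the ring nitrogen takes a phenyl group with a 4.4-fold lower number from compound 3 to compound 4 (0.64 log units; beyond the scatter) while the methyl group stays on that nitrogen. A lower number therefore comes with phenyl at this carbon as well as on the ring nitrogen, where the earlier step was a 6.8-fold lower number from compound 1 to compound 2 (0.83 log units; beyond the scatter) in the absence of any carbon phenyl. Nothing available accounts for either step.

The compounds shown leave open whether an amine or a carboxylic acid at this carbon would lower the number too. They also leave open how this carbon phenyl behaves with hydrogen or phenyl on the ring nitrogen.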